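Methyl for hydrogen on an aryl-bound chain carbon, seen twice

This account rests on a few compounds, and the source may have more. Where it says the series, first, only, none or still open, it means among the compounds named here.

Compound 1, `Cc1cccc(NC(=O)N[C@@H](C)c2ccccc2)c1`: 100%
Compound 2, `CCc1ccccc1NC(=O)N[C@H](C)c1ccccc1`: 100%
Compound 3, `CCc1cccc(NC(=O)N[C@@H](C)c2ccccc2)c1`: 94%

Three ureas have been measured in an ADME assay on the whole organism with Oryza sativa as the target, tested at 1 uM; on this read-out higher numbers stand for a weaker effect at the one concentration tested and lower numbers for a stronger effect. Compound 1 gives 100%, compound 2 gives 100%, and compound 3 gives 94%. Compound 2 stands level with compound 1 at the digits recorded, and the two together hold the highest numbers of the three.

Compound 1 and compound 3 differ in one place, (methyl in place of hydrogen on a saturated chain carbon bound to an aromatic carbon), and the step in this assay was a number 6 percentage points lower from compound 1 to compound 3 (within the scatter).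

The unmeasured compound 4, `CC(C)c1ccccc1NC(=O)N[C@H](C)c1ccccc1`, arises from compound 2 by the same kind of change, (methyl in place of hydrogen on a saturated chain carbon bound to an aromatic carbon and a saturated chain carbon). The two places are not identical: in compound 1 the chain carbon that takes the methyl is bound to an aromatic carbon only, whereas in compound 2 it is bound to an aromatic carbon and a saturated chain carbon. How the core of compound 1 and the core of compound 2 differ from one another is not broken down here.

On this basis the step from compound 2 to compound 4 is expected to be small, a number 4 percentage points lower from compound 2 to compound 4 (within the scatter), because the corresponding step was a number 6 percentage points lower from compound 1 to compound 3 (within the scatter). Compound 4 is therefore estimated to give 96% in this assay, somewhere between 84% and 100%.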

Compound 4, a percentage reported as activity, at one concentration (the size of the read-out at that concentration, not a potency): 101%
For compound 4 the middle estimate is 5 percentage points below the measured one; measured number outside the range, above it.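

In this assay the new step is a number 1 percentage points higher from compound 2 to compound 4 (within the scatter), and this change, which on the core of compound 2 reads as ethyl to isopropyl, gives no separable result there. Set beside the earlier step on the other core, the change shows no difference between the two cores that can be told from the scatter: the same change on two cores in this assay, a number 6 percentage points lower (within the scatter) from compound 1 to compound 3 and a number 1 percentage points higher (within the scatter) from compound 2 to compound 4, 7 percentage points apart, within the scatter of two such steps. This shows only that, for these two pairs, carrying methyl for hydrogen from one core to the other comes with no visible difference in this read-out; it does not show that the change has the same size on every core in the series, nor that it would stay without a clear step elsewhere, and two steps that both lie within the scatter cannot settle either point.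

The compounds shown leave open what a larger group at the same chain carbon, such as tert-butyl or a longer chain, would give in this assay. They also leave open whether a hydroxyl, an amine or a carboxylic acid on that carbon would produce a step beyond the scatter on either core.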